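Chloro added to the fluorophenyl of compound 1

The compounds below may be only part of what the source reports. "The series", "measured", "known", "first", "only" and "open" are said of these compounds alone.

Measured compounds:
compound 1 `CCOC(=O)C1=Cc2ccccc2OC1(OCc1cn(-c2ccc(F)cc2)nn1)C(F)(F)F` gives 8400 nM in a functional assay on HeLa cells (Homo sapiens) for inhibition, read by MTT assay, with a stated time of 24 h; on this read-out lower numbers stand for stronger inhibition and higher numbers for weaker inhibition
compound 2 `O=C(O)C1=Cc2ccccc2OC1(OCc1cc(-c2ccc3ccccc3c2)no1)C(F)(F)F` gives > 150000 nM in this assay

Within the data shown here, compound 1 is the only compound of the pair with a numerical result, and its value of 8400 nM is the sole number on record. For compound 2 the result is a limit, not a number: the reading of > 150000 nM sits at the boundary of what the measurement reports, a case described by the limit of > 150000 nM in this assay, at which 1 of the 2 values shown sits. Among the measured compounds shown here, no step between two measured compounds is available, so no measured step size guides the next move.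

Compound 3 `CCOC(=O)C1=Cc2ccccc2OC1(OCc1cn(-c2ccc(F)c(Cl)c2)nn1)C(F)(F)F` is the next compound, differing from compound 1 by chloro in place of hydrogen on an aromatic carbon. The change is small; the expected step from compound 1 to compound 3 in this assay is a 1.3-fold lower number from compound 1 to compound 3 (0.11 log units; within the scatter), which is judged to lie within the usual scatter. Compound 3 is estimated to give 6500 nM, with a range from 2500 nM to 20000 nM.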

Compound 3, half-maximal inhibitory concentration: 22700 nM
Compound 3: the middle estimate sits 3.5-fold (0.54 log units) below what was measured; measured number above the stated range.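

In this assay the series now has its first measured step, and it is a step towards weaker inhibition: a 2.7-fold higher number from compound 1 to compound 3 (0.43 log units; beyond the scatter) on going from 4-fluorophenyl to 3-chloro-4-fluorophenyl. This shows that the aromatic carbon ortho to a fluoro group and meta to a large group is not indifferent to substitution, and that chloro at this place does not help on this read-out. Nothing on record gives a reason for this step.

From the compounds shown here alone, whether the weakening is particular to chloro or would also follow from another group at this place, such as a methoxy group or an amine, remains open. Also open, going by these compounds, is whether a group at this place can give stronger inhibition than the hydrogen of compound 1.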